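Shortening the Thioether Chain to a Trifluoromethyl Phenyl

The source may hold more compounds than are shown below. What is called first, only, known or untested is meant among the compounds shown, and "the series" means these compounds.

Compound 1, `Cc1cc(Nc2cc(-c3ccccc3)[nH]n2)n2nc(SCCCc3ccccc3)nc2n1`: 3900 nM
Compound 2, `Cc1cc(Nc2cc(-c3ccc(Cl)cc3)[nH]n2)n2nc(SCc3ccc(Br)cc3)nc2n1`: 3620 nM
Compound 3, `Cc1cc(Nc2ccn(Cc3nc(C)c4ccccc4n3)n2)n2nc(SCc3ccc(Br)cc3)nc2n1`: 1430 nM

Of the compounds shown here, three built on one shared core have been tested in a functional assay on MCF7 cells (Homo sapiens) for inhibition, read by MTT assay, with a stated time of 72 h; on this read-out lower numbers stand for stronger inhibition and higher numbers for weaker inhibition. Compound 1 gives 3900 nM in this assay, the highest number of the three. Compound 2, with 3620 nM, lies within the usual scatter of compound 1, so the two cannot be told apart on these data. Compound 3, with 1430 nM, sits clearly lower than compound 1, a gap beyond the scatter.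

Compound 4, `Cc1cc(Nc2cc(-c3ccccc3)[nH]n2)n2nc(SCc3ccc(C(F)(F)F)cc3)nc2n1`, has not yet been measured. It differs from compound 1 in a single place: 4-(trifluoromethyl)phenyl in place of phenethyl on a saturated chain carbon bound to a sulfur. Among the compounds with values here, no measured pair isolates this change. Compounds 2 and 3 each differ from compound 1 in more than one place at once, so they show only that other variants on this core can reach lower numbers than compound 1, without singling out the thioether side.

On that basis compound 4 is expected to come in somewhat lower than compound 1, and the step of a 1.4-fold lower number from compound 1 to compound 4 (0.14 log units; within the scatter) is expected to be small, close to the edge of the scatter. The estimate for compound 4 in this assay is 2800 nM, with a range from 1200 nM to 6500 nM.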

Compound 4, half-maximal inhibitory concentration: 4820 nM
The estimate for compound 4 lay 1.7-fold (0.24 log units) below the measured number, within the range that was stated.
By their numbers in this assay, from the lowest: compound 3; then compounds 2, 1 and 4 (each within the scatter of the next).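

In this assay, within the data shown here, putting 4-(trifluoromethyl)phenyl in place of phenethyl on a saturated chain carbon bound to a sulfur gives a 1.2-fold higher number from compound 1 to compound 4 (0.09 log units; within the scatter) and this is the first pair here in which the thioether side is the only thing that differs. Read one bond further out, 3-phenylpropyl and 4-(trifluoromethyl)benzyl cannot be told apart on this read-out, so this exchange at this position has no detectable effect on the number in this assay. No measurement shown here speaks to the reason for this result.

From the compounds shown here alone, the step also alters the chain and the ring together, so it remains open whether either alteration alone would leave the number as unchanged, as a comparison with a plain benzyl group in this place could help to show. Going by these compounds, it is equally open whether a group of a different kind on the thioether side, such as an amine or a carboxylic acid, would produce a step beyond the scatter.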